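Swapping methoxy for isopropoxy on compound 2

A few compounds are considered here, and "the series" means these few. Any claim that something is new, unique, unknown or untested is made for them only; others in the source may bear on it.

Among the compounds with values here, in a functional assay on A549 cells (Homo sapiens) for antiproliferative activity, read by MTT assay, with a stated time of 48 h (on this read-out higher numbers stand for weaker inhibition and lower numbers for stronger inhibition), compound 2 (`COc1cc(-c2nnc3c(OC)cc(-c4ccc5c(ccn5C)c4)cn23)cc(OC)c1OC`) gives 69 nM as the lower of the two numbers measured so far. Compound 1 (`COc1cc(-c2nnc3c(OC(C)C)cc(-c4ccc5[nH]ccc5c4)cn23)cc(OC)c1OC`) gives 1250 nM in the same test, a gap beyond the usual scatter, but these two compounds differ in more than one place. Compound 3 (`COc1cc(-c2nnc3c(OC(C)C)cc(-c4ccc5c(ccn5C)c4)cn23)cc(OC)c1OC`) has isopropyl in place of methyl on an oxygen on an aromatic ring, a change of methoxy to isopropoxy (isopropyl in place of methyl on an oxygen on an aromatic ring) on compound 2. Within the data shown here, no measured pair shows this change alone. Compound 1 also carries isopropoxy and stands at 1250 nM in this assay as the only hint available, so a moderate move towards weaker inhibition, beyond the scatter, is expected. The expected change is a 4.1-fold higher number from compound 2 to compound 3 (0.61 log units; beyond the scatter) in this test. For compound 3 the estimate is 280 nM with 80 nM to 1000 nM as its expected range.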

Compound 3, half-maximal inhibitory concentration: 322 nM
Compound 3: middle estimate off by 1.2-fold (0.06 log units), on the low side; the measured number falls inside the stated range.
By their numbers in this assay, from the lowest: compound 2; then compound 3; then compound 1.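

In this assay, the swap of methoxy for isopropoxy can now be read on its own: with everything else held the same, it gives a 4.7-fold higher number from compound 2 to compound 3 (0.67 log units; beyond the scatter), so inhibition on this oxygen on an aromatic ring weakens with isopropyl in place of methyl. Compound 3 also isolates a second place, where methyl in place of hydrogen on an aromatic nitrogen gives a 3.9-fold lower number from compound 1 to compound 3 (0.59 log units; beyond the scatter), so with isopropoxy in the molecule, this methyl goes with stronger inhibition. Nothing shown here explains either step.

On these data alone, with only methoxy and isopropoxy on this oxygen, it remains open how an ethoxy group, a longer chain or a chain ending in an amine would behave there. As far as these compounds go, it is also open whether the methyl on the nitrogen gives a similar step when methoxy sits on the oxygen.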